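Clearance notes: compound 1 towards compound 3

A few compounds are considered here, and "the series" means these few. Any claim that something is new, unique, unknown or untested is made for them only; others in the source may bear on it.

- compound 1 `Cc1ccc(NC(=O)[C@H](CC2CCCC2)n2cnc(C(F)(F)F)c2)nc1`: > 120 mL/min/kg (a limit, not a number)
- compound 2 `O=C(Nc1ccc(-c2nnn[nH]2)cn1)[C@H](CC1CCCC1)n1cnc(C(F)(F)F)c1`: 160 mL/min/kg

In an in vitro ADME assay on microsomes from liver (Homo sapiens) for metabolic stability (on this read-out lower numbers stand for slow clearance and higher numbers for fast clearance), compound 1 gives only a limit, > 120 mL/min/kg. For the measured compounds named here, the evidence for the series so far amounts to the limit of > 120 mL/min/kg in this assay, at which 1 of the 2 values shown sits.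

The next compound is compound 3 `O=C(O)Cn1ccc(NC(=O)[C@H](CC2CCCC2)n2cnc(C(F)(F)F)c2)n1`, which replaces the 5-methylpyridin-2-yl on the amide-type nitrogen: 1-(carboxymethyl)-1H-pyrazol-3-yl in place of 5-methylpyridin-2-yl on an amide-type nitrogen.

Going by the values given here, only one measured step bears on this change, a step that the limit leaves unreadable from compound 1 to compound 2, and it gives no size to carry over. It swaps a different group at a different place. What it does show is that compound 2 still clears fast, at 160 mL/min/kg. On that basis, no clear step and no firm direction are expected in this assay. The estimated change is an at least 1.0-fold lower number from compound 1 to compound 3 (0.03 log units; that floor lies within the scatter). Compound 3 is expected at 110 mL/min/kg, with an estimated range of 45 mL/min/kg to 230 mL/min/kg.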

Compound 3, clearance: < 8 mL/min/kg
Compound 3: only a limit was reported (the forecaster's own chance of this, stated with the estimate: 30%); middle value at least 13-fold (1.13 log units) away from the limit.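

For the compounds shown here, replacing 5-methylpyridin-2-yl with 1-(carboxymethyl)-1H-pyrazol-3-yl on the amide-type nitrogen gives the first readable step in this assay, an at least 15-fold lower number from compound 1 to compound 3 (1.17 log units; beyond the scatter); the step to compound 2 cannot be read. Compound 3 gives < 8 mL/min/kg, which is a limit. The group on the amide-type nitrogen can therefore shift this read-out strongly, something compound 2, at 160 mL/min/kg, did not show.

The step exchanges the ring and brings in the carboxymethyl group together, and the compounds shown do not separate the two. The same 1H-pyrazol-3-yl ring bearing a plain methyl, a methyl ester in place of the carboxylic acid, or a longer chain ending in the carboxylic acid would each bear on that question.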